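A 4-fluorophenyl to 4-chlorophenyl swap

The source may report more compounds than this note shows. Statements on the series, on what has been measured and on what is new or still open speak of the compounds shown alone.

In a functional assay on A549 cells (Homo sapiens) for antiproliferative activity, read by MTT assay, with a stated time of 48 h (a higher number here means a weaker inhibitor, a lower number a stronger inhibitor), compound 3 `Oc1ccc2ccccc2c1C(Nc1nc2ccc(Cl)cc2s1)c1cn(-c2ccccc2)nc1-c1ccc(F)cc1` gives 32200 nM. The other measured compounds are compound 1 `Oc1ccc2ccccc2c1C(Nc1nc2ccccc2s1)c1cn(-c2ccccc2)nc1-c1ccc(I)cc1`, which gives 23100 nM, and compound 2 `COc1ccc2nc(NC(c3cn(-c4ccccc4)nc3-c3ccc(F)cc3)c3c(O)ccc4ccccc34)sc2c1`, which gives 33600 nM. These three values all lie within the usual scatter of one another, so compound 3 stands level with both and no ranking can be drawn.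

The next molecule, compound 4 `Oc1ccc2ccccc2c1C(Nc1nc2ccc(Cl)cc2s1)c1cn(-c2ccccc2)nc1-c1ccc(Cl)cc1`, carries a single change: chloro in place of fluoro on an aromatic carbon. In words, this is chloro in place of fluoro on an aromatic carbon, turning 4-fluorophenyl into 4-chlorophenyl.

Among the measured compounds shown here, no measured step tests this swap directly. The nearest evidence is a different change at another place in the molecule, chloro in place of methoxy on an aromatic carbon. Because that change gave only a 1.0-fold lower number from compound 2 to compound 3 (0.02 log units; within the scatter), no step beyond the scatter is expected in this assay. The expected change is a 1.1-fold lower number from compound 3 to compound 4 (0.05 log units; within the scatter). Compound 4 is estimated at 29000 nM, with an expected range of 15000 nM to 50000 nM.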

Compound 4, half-maximal inhibitory concentration: 54100 nM
The estimate for compound 4 lay 1.9-fold (0.27 log units) below the measured number; the whole stated range lies below it.
By their numbers in this assay, from the lowest: compounds 1, 3, 2 and 4 (each within the scatter of the next, the first and the last beyond it).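

Among the compounds shown here, this is the first direct reading of the 4-fluorophenyl to 4-chlorophenyl swap: with everything else in the molecule unchanged, this assay shows a 1.7-fold higher number from compound 3 to compound 4 (0.23 log units; within the scatter). On an aromatic carbon of this ring, chloro and fluoro therefore cannot be told apart in this assay, even though this step is wider than the one seen earlier for chloro in place of methoxy elsewhere in the molecule. No measurement of any property of these compounds comes with this result, and nothing here accounts for the size of the step.

From the compounds shown here alone, whether an amine or a carboxylic acid at this same position would give a step beyond the scatter remains open. So does whether the swap would read the same in other cell lines or with a different group elsewhere on the shared core.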